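Adding a (Benzylamino)methyl Group to Compound 3

The source may hold more compounds than are shown below. What is called first, only, known or untested is meant among the compounds shown, and "the series" means these compounds.

Measured compounds:
compound 1 `COc1cc(Nc2nc(C#N)cc3c(C(C)C)n[nH]c23)cc(OC)c1OC` gives 3.8 nM
compound 2 `N#Cc1cc2c(-c3ccccc3)n[nH]c2c(Nc2ccccc2)n1` gives 60.3 nM
compound 3 `COc1cc(Nc2nccc3c(-c4ccccc4)n[nH]c23)cc(OC)c1OC` gives 5.13 nM

The three compounds above were tested in a functional assay on Flp-In-CHO cells for antagonist activity at adenosine receptor A3 (Homo sapiens), read by cAMP accumulation, with a stated time of 30 min; a lower number here means a stronger inhibitor, a higher number a weaker inhibitor. Compound 3 stands second highest of the three numbers. Its value and that of compound 1 lie within the usual scatter of each other, so no order can be read between them, while compound 2 gives a higher number that lies beyond the scatter. Compound 1 and compound 2 both carry a nitrile where compound 3 carries hydrogen, but each of them differs from compound 3 in a second place as well, so none of these pairs yields a single step.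

Compound 4 `COc1cc(Nc2nc(CNCc3ccccc3)cc3c(-c4ccccc4)n[nH]c23)cc(OC)c1OC` differs from compound 3 by (benzylamino)methyl in place of hydrogen on an aromatic carbon. Among the measured compounds shown here, no measured pair in this assay shows this change, so the expectation rests only on the three numbers and the size of the group that enters. The step of a 2.3-fold higher number from compound 3 to compound 4 (0.37 log units; beyond the scatter) is expected to be modest and toward a somewhat higher number, though a change within the scatter would not be surprising. Compound 4 is therefore expected to give about 12 nM, with a likely range from 3 nM to 60 nM.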

Compound 4, half-maximal inhibitory concentration: 7.24 nM
Compound 4: middle estimate off by 1.7-fold (0.22 log units), on the high side; low and high end bracket the measured number.
By their numbers in this assay, from the lowest: compounds 1, 3 and 4 (each within the scatter of the next); then compound 2.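

In this assay, (benzylamino)methyl in place of hydrogen on the aromatic carbon next to the ring nitrogen gives a 1.4-fold higher number from compound 3 to compound 4 (0.15 log units; within the scatter). Among the compounds shown here, this is the first single-place step at this carbon, which also carries the nitrile in compound 1 and compound 2, though a second difference from compound 3 in each of those compounds kept any effect from being read there alone. The step shows that this carbon can bear a group of this size, with its six-membered aromatic ring of carbon only, while the number stays within the scatter of the value for compound 3, and nothing at hand explains this result.

A single step cannot show whether the outcome depends on the benzyl ring, the amine or the methylene link, so a plain aminomethyl group, a benzyloxymethyl group or a longer chain ending in a phenyl ring would each be needed to separate these parts. From the compounds shown here alone, it also remains open how a nitrile alone, or a carboxylic acid, would behave at this carbon on the core of compound 3.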